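A few compounds are considered here, and "the series" means these few. Any claim that something is new, unique, unknown or untested is made for them only; others in the source may bear on it.

Compound 1 `Cc1cccc(NC(=O)Nc2cccc(CNc3ncnc4ccccc34)c2)c1` and compound 2 `O=C(Nc1cccc(CNc2ncnc3ccccc23)c1)Nc1ccccc1Cl` share one core. In a functional assay on HepG2 cells (Homo sapiens) for antiproliferative activity, read by MTT assay (a lower number here means a stronger inhibitor, a higher number a weaker inhibitor), compound 1 gives > 50000 nM, which is a limit of the assay and not a number. Compound 2 likewise reaches only a limit in this assay, > 50000 nM. The change of 2-chlorophenyl in place of 3-methylphenyl on an amide-type nitrogen therefore yields a step that the two limits leave unreadable from compound 1 to compound 2. Compound 3 `COc1cc2ncnc(NCc3cccc(NC(=O)Nc4ccc(C)cc4)c3)c2cc1OC` also stands at a limit in this assay, > 50000 nM. Every value shown so far sits at the same point, (the limit of > 50000 nM in this assay, at which 3 of the 3 values shown sit), so compound 3 can be placed only at that limit and nowhere within the scale of numbers.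

Compound 4 `COc1cc2ncnc(NCc3cccc(NC(=O)Nc4ccc(F)cc4)c3)c2cc1OC` differs from compound 3 by fluoro in place of methyl on an aromatic carbon, para to a large group. Among the measured compounds shown here, no measured step bears on this change in a readable way: the single step measured runs between two limits and has no size. What remains is the position of compound 3 itself at the limit. Compound 4 is therefore expected to give 60000 nM in this assay, with a range from 20000 nM to 200000 nM, most probably again only as a limit. The step this estimate means, a step that the limit leaves unreadable from compound 3 to compound 4, is expected to stay within the scatter.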

Compound 4, half-maximal inhibitory concentration: 36600 nM
The estimate for compound 4 lay 1.6-fold (0.21 log units) above the measured number, within the range that was stated.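

In this assay the series gains its first readable number with fluoro in place of methyl on an aromatic carbon, para to a large group, and this change gives an at least 1.3-fold lower number from compound 3 to compound 4 (0.13 log units; that floor lies within the scatter) on the shared core. Compound 3 is held only at a limit, so this size is a floor and not a full step: the real difference may be larger, but the floor alone does not show that the change reaches beyond the scatter. Compound 4 is the one compound shown that can be placed on the scale of numbers, while the others rest at a single point: the limit of > 50000 nM in this assay, at which 3 of the 4 values shown sit.

The compounds shown leave open whether the number belongs to fluoro in particular or whether another replacement for methyl at this position, such as an amine or a carboxylic acid, would also bring a value below the limit. They also leave open whether 4-fluorophenyl would lift the core of compound 1 off its limit in the same way, and so whether this single result holds beyond the core of compound 3.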